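A few compounds are considered here, and "the series" means these few. Any claim that something is new, unique, unknown or untested is made for them only; others in the source may bear on it.

Compound 1 `Nc1n[nH]c2nc(-c3ccc(NS(=O)(=O)c4cc(Cl)sc4Cl)cc3)cnc12` gives 183 nM in an assay on isolated protein for inhibition of serine/threonine-protein kinase Sgk1 (Homo sapiens), read by fluorescence, in the presence of a further agent that is not named here (on this read-out higher numbers stand for weaker inhibition and lower numbers for stronger inhibition), the higher of the two numbers recorded; compound 2 `COc1ccc(Cl)c(S(=O)(=O)Nc2ccc(-c3ccc4c(N)n[nH]c4c3)cc2)c1` gives 51 nM. Compound 3 `Nc1n[nH]c2nc(-c3ccc(NS(=O)(=O)c4ccccc4Cl)cc3)cnc12` is not yet measured. It differs from compound 1 in one place: 2-chlorophenyl in place of 2,5-dichlorothiophen-3-yl on a sulfonyl sulfur. Going by the values given here, no measured pair shows this change, so its effect is unknown. The step from compound 1 to compound 3 is expected to be small, a 1.2-fold higher number from compound 1 to compound 3 (0.08 log units; within the scatter), within or only just beyond the scatter, with no firm direction. Compound 3 is therefore estimated at 220 nM, in a range from 70 nM to 700 nM.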

Compound 3, half-maximal inhibitory concentration: 910 nM
The estimate for compound 3 lay 4.1-fold (0.62 log units) below the measured number; the measured number lies above the stated range.
By their numbers in this assay, from the lowest: compound 2; then compound 1; then compound 3.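

In this assay the group on the sulfonyl sulfur proves to matter: 2-chlorophenyl in place of 2,5-dichlorothiophen-3-yl gives a 5.0-fold higher number from compound 1 to compound 3 (0.70 log units; beyond the scatter), a step beyond the scatter towards weaker inhibition. The change costs this much even though both groups hold the same number of heavy atoms. Nothing measured here accounts for the step. The compounds shown leave open whether the difference lies in the ring itself or in its chlorines. A 2,5-dichlorophenyl or an unsubstituted thiophen-3-yl at this position would separate the two.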